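A few compounds are considered here, and "the series" means these few. Any claim that something is new, unique, unknown or untested is made for them only; others in the source may bear on it.

In a functional assay on MCF7 cells (Homo sapiens) for cytotoxicity, read by MTT assay, with a stated time of 72 h (a higher number here means a weaker inhibitor, a lower number a stronger inhibitor), compounds sharing one core give high numbers where a number is reported at all. Compound 1 (`Cn1ccc2c(Oc3ccc(NC(=O)c4cc5cccnc5n(-c5ccc(Cl)cc5)c4=O)cc3)ncnc21`) gives 95000 nM, and compound 2 (`COc1ccc(-n2c(=O)c(C(=O)Nc3ccc(Oc4ncnc5c4ccn5C)cc3)cc3cccnc32)cc1`) gives 105000 nM. Among the measured compounds shown here, compound 3 (`Cn1ccc2c(Oc3ccc(NC(=O)c4cc5cccnc5n(-c5ccc(C(F)(F)F)cc5Cl)c4=O)cc3)ncnc21`) is recorded as "not active" (no number reported), so it stands without a number and no step can be measured from it.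

Compound 4 (`Cn1ccc2c(Oc3ccc(NC(=O)c4cc5cccnc5n(-c5ccc(C(F)(F)F)c(Cl)c5)c4=O)cc3)ncnc21`) has the same atoms as compound 3, joined differently: 3-chloro-4-(trifluoromethyl)phenyl in place of 2-chloro-4-(trifluoromethyl)phenyl on an aromatic nitrogen. In words, 3-chloro-4-(trifluoromethyl)phenyl stands in place of 2-chloro-4-(trifluoromethyl)phenyl on an aromatic nitrogen.

For the measured compounds named here, only one measured step bears on this change, and only loosely. It is a 1.1-fold higher number from compound 1 to compound 2 (0.04 log units; within the scatter), with methoxy in place of chloro on an aromatic carbon. Going by the values given here, no measured step moves a chloro group from one place to another, so the data give no direct size for this change. With compound 3 lacking a number, no step size or direction from it can be expected in this assay. The best available guide is the small step shown by the two measured compounds, and compound 4 may also return no number. Compound 4 is expected at about 100000 nM, with an estimated range from 40000 nM to 200000 nM.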

Compound 4, half-maximal inhibitory concentration: "not active" (no number reported)
Compound 4: no number reported, and the estimate cannot be compared.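

In this assay compound 3 and compound 4 are both recorded as "not active", with no number for either, so no step can be read between them. No measured evidence bears on this result. The compounds shown leave open whether 2-chloro-4-(trifluoromethyl)phenyl and 3-chloro-4-(trifluoromethyl)phenyl differ at all in their effect on these cells.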